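The source may report more compounds than this note shows. Statements on the series, on what has been measured and on what is new or still open speak of the compounds shown alone.

Compound 1 `Cc1nn(C)c2c1C(c1ccc(OC(F)(F)F)cc1)C(C#N)=C(N)O2` gives 2900 nM in a functional assay on NCI-H2122 cells (Homo sapiens) for inhibition, read by microscopy, with a stated time of 10 days; on this read-out higher numbers stand for weaker inhibition and lower numbers for stronger inhibition. Compound 2 `Cn1nc(-c2ccccc2)c2c1OC(N)=C(C#N)C2c1ccc(OC(F)(F)F)cc1` carries the change (phenyl in place of methyl on an aromatic carbon), and in this assay compound 2 gives 5500 nM, a step of a 1.9-fold higher number from compound 1 to compound 2 (0.28 log units; within the scatter). Compound 3 `Cc1nn(C)c2c1C(c1cccnc1)C(C#N)=C(N)O2` rests on a different core; how the cores of compound 1 and compound 3 differ is not broken down here. In this assay compound 3 gives 8800 nM. Compound 4 `Cn1nc(-c2ccccc2)c2c1OC(N)=C(C#N)C2c1cccnc1` has not yet been measured; it carries the same change, (phenyl in place of methyl on an aromatic carbon), at the same place. Going by the values given here, for compound 4 the step is expected to match the earlier one, a 1.8-fold higher number from compound 3 to compound 4 (0.26 log units; within the scatter), because a 1.9-fold higher number from compound 1 to compound 2 (0.28 log units; within the scatter) is the only instance of this change seen so far, and that rests on a single pair. Compound 4 is therefore estimated at 16000 nM, with a range from 6000 nM to 40000 nM.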

Compound 4, half-maximal inhibitory concentration: > 10000 nM
Compound 4 was reported as a limit; the forecaster's own chance of this, stated with the estimate: 20%; the middle value does not contradict the limit.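

In this assay compound 4 gives > 10000 nM, which is a limit of the assay and not a number. Phenyl in place of methyl on an aromatic carbon gives the step of an at least 1.1-fold higher number from compound 3 to compound 4 (0.05 log units; that floor lies within the scatter), and this is only a floor, so the comparison with the earlier core stays incomplete: the same change on two cores in this assay, a 1.9-fold higher number (0.28 log units; within the scatter) from compound 1 to compound 2 and an at least 1.1-fold higher number (0.05 log units; that floor lies within the scatter) from compound 3 to compound 4; the limit leaves it open whether they differ The result is compatible with the change carrying over from one core to the other, but it does not show that it does, and the true size of the step on the second core stays unknown: the limit of > 10000 nM in this assay, at which 1 of the 4 values shown sits.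

The compounds shown leave open how an amine or a longer chain on that aromatic carbon would read in this assay. They also leave open how the change would behave on any further core.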